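The source may hold more compounds than are shown below. What is called first, only, known or untested is meant among the compounds shown, and "the series" means these compounds.

Compound 1 `CCNc1nc(N)c2nc(O)n(Cc3ccccc3)c2n1` gives 1 uM in a functional assay (spleen, spleen) for activation, with Mus musculus as the target; a higher number here means that more compound is needed for the effect, a lower number that less compound is needed.
Compound 2 `CCCCCNc1nc(N)c2nc(O)n(Cc3ccccc3)c2n1` gives 0.1 uM in this assay.
Compound 3 `Nc1ncnc2c1nc(Cl)n2Cc1ccccc1` gives > 10 uM in this assay, which is a limit of the assay and not a number.

Among the measured compounds the only step between neighbours is a 10-fold lower number from compound 1 to compound 2 (1.00 log units; beyond the scatter). Compound 3 stands apart: its result is the limit of > 10 uM in this assay, at which 1 of the 3 values shown sits, a limit, so it has no number of its own to compare.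

Compound 4 `NNc1nc2c(N)ncnc2n1Cc1ccccc1` differs from compound 3 in one place: aminoamino in place of chloro on an aromatic carbon. Among the compounds with values here, the measured step from compound 1 to compound 2 concerns a saturated chain carbon, not the aromatic carbon changed here, so no measured step bears on this change, and its size and direction cannot be read from the data. Within the data shown here, the only anchor is compound 3, whose value is a limit. The estimate for compound 4 in this assay is 3 uM, with a range of 0.3 uM to 30 uM. The expected step is an at least 3.3-fold lower number from compound 3 to compound 4 (0.52 log units; beyond the scatter), with a real chance that compound 4 also returns only a limit.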

Compound 4, minimum effective concentration: > 10 uM
Compound 4 ended at the assay's limit; the forecaster's own chance of this, stated with the estimate: 40%; middle value at least 3.3-fold (0.52 log units) from the limit.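

Compound 3 and compound 4 both end at a limit of the assay, so no step can be read between them: the limit of > 10 uM in this assay, at which 2 of the 4 values shown sit.

The compounds shown leave open whether aminoamino in place of chloro on an aromatic carbon changes the result in this assay at all, and in which direction.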